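Replacing 1-hydroxyethyl with hydrogen in compound 3

A few compounds are considered here, and "the series" means these few. Any claim that something is new, unique, unknown or untested is made for them only; others in the source may bear on it.

Compound 3 (`C=C1[C@H](C)CCC[C@]1(C)CC/C(C)=C/CC1=C(O)C(=O)C=C(N[C@@H](C(=O)O)[C@@H](C)O)C1=O`) gives > 10 ug/mL in an ADME assay on L1210 cells (Mus musculus) for cytotoxicity, with a stated time of 48 h (a lower number here means a stronger inhibitor, a higher number a weaker inhibitor), as a limit of the assay, not a number. Compound 2 (`C=C1[C@H](C)CCC[C@]1(C)CC/C(C)=C/CC1=C(O)C(=O)C=C(N[C@H](C(=O)O)[C@@H](C)O)C1=O`) gives > 10 ug/mL there, again a limit. Compound 1 (`C=C1[C@H](C)CCC[C@]1(C)CC/C(C)=C/CC1=C(O)C(=O)C=C(N[C@@H](C(=O)O)[C@H](C)O)C1=O`) alone has a number, at 4.6 ug/mL on the same read-out. Compound 4 (`C=C1[C@H](C)CCC[C@]1(C)CC/C(C)=C/CC1=C(O)C(=O)C=C(NCC(=O)O)C1=O`) carries hydrogen in place of 1-hydroxyethyl on a saturated chain carbon bound to an amine nitrogen and a carbonyl carbon. The nearest measured steps change configuration only. Two are at least modest (an at least 2.1-fold higher number from compound 1 to compound 2 (0.33 log units; beyond the scatter); an at least 2.1-fold higher number from compound 1 to compound 3 (0.33 log units; beyond the scatter)) and one is unreadable (a step that the two limits leave unreadable from compound 2 to compound 3). None measures this replacement, so at most a modest move to a lower number is expected (an at least 1.2-fold lower number from compound 3 to compound 4 (0.09 log units; that floor lies within the scatter)). For compound 4 the estimated value is 8 ug/mL (expected range 3 ug/mL to 20 ug/mL).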

Compound 4, half-maximal inhibitory concentration: 4 ug/mL
Compound 4: the middle estimate sits 2.0-fold (0.30 log units) above what was measured; measured number inside the range.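

In this assay, compound 4 cannot be told apart from compound 1, which carries 1-hydroxyethyl: a 1.2-fold lower number from compound 1 to compound 4 (0.06 log units; within the scatter). Against the other two configurations the same replacement does register, with an at least 2.5-fold lower number from compound 3 to compound 4 (0.39 log units; beyond the scatter) and an at least 2.5-fold lower number from compound 2 to compound 4 (0.39 log units; beyond the scatter), so at this saturated chain carbon the 1-hydroxyethyl group is not required for a reading of this size. Compounds 2 and 3 stand only as limits of the assay, not numbers, and these two steps give only a floor: the limit of > 10 ug/mL in this assay, at which 2 of the 4 values shown sit.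

Still open, as far as these compounds go, is whether a methyl group at this carbon would read like compound 4 or like compounds 2 and 3. Also open, from the compounds shown here alone, is how a methyl ester in place of the carboxylic acid would read.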